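A few compounds are considered here, and "the series" means these few. Any claim that something is new, unique, unknown or untested is made for them only; others in the source may bear on it.

The study concerns four analogues built on two related cores. Compound 1, `COc1cc2c(/C=C3/C(=O)N(C)c4ccccc43)c(Cl)n(C)c2cc1C`, and compound 2, `COc1cc2c(/C=C3/C(=O)N(C)c4ccc(O)cc43)c(Cl)n(C)c2cc1C`, share one core; compound 3, `COc1cc2c(/C=C3/C(=O)N(C)c4ccccc43)c[nH]c2cc1C`, and the not yet measured compound 4, `COc1cc2c(/C=C3/C(=O)N(C)c4ccc(O)cc43)c[nH]c2cc1C`, share the other. How the two cores differ is not broken down here.

In a functional assay on cells (Melanoma cell, Homo sapiens) for inhibition, with a stated time of 48 h (on this read-out lower numbers stand for stronger inhibition of growth and higher numbers for weaker inhibition of growth), compound 1 gives 340 nM, and compound 2 gives 110 nM. Between them stands a single change, (hydroxy in place of hydrogen on an aromatic carbon), and that change produced a 3.1-fold lower number from compound 1 to compound 2 (0.49 log units; beyond the scatter). Compound 3 gives 3090 nM in this assay, the highest of the three numbers, standing beyond the scatter from both compound 1 and compound 2.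

Compound 4 is related to compound 3 by exactly the change that relates compound 2 to compound 1: hydroxy in place of hydrogen on an aromatic carbon. The place of the change is the same in both pairs. The expectation therefore rests on the measured step of a 3.1-fold lower number from compound 1 to compound 2 (0.49 log units; beyond the scatter). On that basis the step of a 3.1-fold lower number from compound 3 to compound 4 (0.49 log units; beyond the scatter) is expected in this assay. Compound 4 is accordingly estimated at 1000 nM in this assay, with a plausible range from 450 nM to 2300 nM.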

Compound 4, concentration for 50% growth inhibition: 3240 nM
Estimate against measurement, compound 4: 3.2-fold (0.51 log units) below, and the stated range ends below it.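

In this assay the hydroxy group in place of hydrogen on an aromatic carbon gave a 1.0-fold higher number from compound 3 to compound 4 (0.02 log units; within the scatter) and so the gain seen on the core of compound 1 did not appear on the core of compound 3. This change therefore did not carry over from one core to the other, as setting the two pairs side by side shows: the same change on two cores in this assay, a 3.1-fold lower number (0.49 log units; beyond the scatter) from compound 1 to compound 2 and a 1.0-fold higher number (0.02 log units; within the scatter) from compound 3 to compound 4, 3.2-fold (0.51 log units) apart, beyond the scatter of two such steps. The result rests on a single pair for each core in one cell assay, so it shows that the outcome of this change depends on the core here, but it does not show which difference between the cores is responsible or how the change would behave on any other core in the series.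

The compounds shown leave open whether an amine or a carboxylic acid in place of the hydroxy group would also differ between the two cores. They also leave open whether a hydroxy group on another aromatic carbon would do so.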